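Swapping a hydroxy for an anilino group: little change so far

This account rests on a few compounds, and the source may have more. Where it says the series, first, only, none or still open, it means among the compounds named here.

Of the compounds shown here, three that share one core have been tested for how strongly they slow the growth of lung cancer cells. Compound 1 `O=C(C1=C(O)C(=O)N(CCCn2ccnc2)C1c1ccc(Br)cc1)c1ccccc1` carries a hydroxy group on a double-bonded ring carbon; in a functional assay on NCI-H1299 cells (Homo sapiens) for antiproliferative activity, read by MTT assay, with a stated time of 72 h (a higher number here means a weaker inhibitor, a lower number a stronger inhibitor), compound 1 gives 20000 nM. Compound 2 `O=C(C1=C(Nc2ccccc2)C(=O)N(CCCn2ccnc2)C1c1ccc(Br)cc1)c1ccccc1` bears an anilino group at that carbon and in this assay compound 2 gives 21200 nM; the step of a 1.1-fold higher number from compound 1 to compound 2 (0.03 log units; within the scatter). Compound 3 `CCOc1ccc(NC2=C(C(=O)c3ccccc3)C(c3ccc(Br)cc3)N(CCCn3ccnc3)C2=O)cc1` has a (4-ethoxyphenyl)amino group there, and in this assay compound 3 gives 20000 nM; the step of no change at the digits printed from compound 1 to compound 3 (within the scatter), and from the anilino compound the step of a 1.1-fold lower number from compound 2 to compound 3 (0.03 log units; within the scatter). So compound 1 stands at the same number as compound 3, with compound 2 within the scatter of both.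

Compound 4 `O=C(C1=C(Nc2ccc(OC(F)(F)F)cc2)C(=O)N(CCCn2ccnc2)C1c1ccc(Br)cc1)c1ccccc1` is the next member of this set. It differs from compound 1 in one place: (4-(trifluoromethoxy)phenyl)amino in place of hydroxy on a double-bonded ring carbon. The two measured steps that bear on this change, a 1.1-fold higher number from compound 1 to compound 2 (0.03 log units; within the scatter) and no change at the digits printed from compound 1 to compound 3 (within the scatter), both put an arylamino group in place of the hydroxy and both stayed within the scatter. A step of that size is therefore expected here too, with no clear direction: in this assay compound 4 is expected to give about 20000 nM, likely between 8000 nM and 50000 nM, meaning an expected step of no change at the digits printed from compound 1 to compound 4 (within the scatter).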

Compound 4, half-maximal inhibitory concentration: 11500 nM
Beside the measured number, compound 4's estimate is 1.7-fold (0.24 log units) above it; low and high end bracket the measured number.
By their numbers in this assay, from the lowest: compounds 4, 1, 3 and 2 (each within the scatter of the next).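

The hydroxy on this double-bonded ring carbon can give way to a third arylamino group, this one bearing trifluoromethoxy, and in this assay the outcome is a 1.7-fold lower number from compound 1 to compound 4 (0.24 log units; within the scatter) and so adds a second kind of substituent to the earlier result. On the aromatic ring of the arylamino group, trifluoromethoxy in place of hydrogen gives a 1.8-fold lower number from compound 2 to compound 4 (0.27 log units; within the scatter) while trifluoromethyl in place of ethyl on the oxygen gives a 1.7-fold lower number from compound 3 to compound 4 (0.24 log units; within the scatter) and neither step separates the compounds. With hydrogen, ethoxy or trifluoromethoxy on that aromatic ring, all four compounds shown now lie within the scatter of one another, whether the ring carbon carries hydroxy or an arylamino group.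

As far as these compounds go, it remains open whether a different kind of group at this carbon, such as a dimethylamino group, a carboxylic acid or a benzylamino group with its longer chain, would move the number beyond the scatter. The benzoyl, 4-bromophenyl and 3-(1H-imidazol-1-yl)propyl groups are the same in all four compounds, so what each contributes cannot be read from this set.

No measured evidence here accounts for how closely these numbers sit together.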